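The compounds below may be only part of what the source reports. "The series", "measured", "known", "first", "only" and "open" are said of these compounds alone.

Within the shared core of compound 1 `O=C1NCCC12CCN(c1c(Cl)cncc1-c1ccsc1)CC2`, three variants of the five-membered ring have been measured so far. In a functional assay on MV4-11 cells (Homo sapiens) for inhibition, read by resazurin assay, with a stated time of 72 h (on this read-out lower numbers stand for stronger inhibition of growth and higher numbers for weaker inhibition of growth), compound 1 gives 190 nM, the lowest number of the three. Compound 2 `O=Cc1ccc(-c2cncc(Cl)c2N2CCC3(CCNC3=O)CC2)o1` gives 5190 nM in this assay, and compound 3 `Cc1csc(-c2cncc(Cl)c2N2CCC3(CCNC3=O)CC2)c1` gives 650 nM. The steps are a 27-fold higher number from compound 1 to compound 2 (1.44 log units; beyond the scatter) and a 3.4-fold higher number from compound 1 to compound 3 (0.53 log units; beyond the scatter); between the two substituted rings, an 8.0-fold lower number from compound 2 to compound 3 (0.90 log units; beyond the scatter).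

Compound 4 `CC(=O)c1sccc1-c1cncc(Cl)c1N1CCC2(CCNC2=O)CC1` is not yet measured. Relative to compound 1 the difference is acetyl in place of hydrogen on an aromatic carbon, the ring itself being kept. Among the measured compounds shown here, no measured pair isolates this exact change. The nearest guides are the two steps away from compound 1: placing a 5-formylfuran-2-yl in place of thiophen-3-yl cost a 27-fold higher number from compound 1 to compound 2 (1.44 log units; beyond the scatter), and a 4-methylthiophen-2-yl in place of thiophen-3-yl cost a 3.4-fold higher number from compound 1 to compound 3 (0.53 log units; beyond the scatter); both moves away from the unsubstituted ring raised the number beyond the scatter. On that basis a modest increase is expected for compound 4, roughly a 4.7-fold higher number from compound 1 to compound 4 (0.68 log units; beyond the scatter). Compound 4 is therefore estimated at 900 nM in this assay, with a range of 300 nM to 3000 nM.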

Compound 4, concentration for 50% growth inhibition: > 100000 nM
Compound 4: a limit, no number; the forecaster's own chance of this, stated with the estimate: 3%; at least 110-fold (2.04 log units) between middle value and limit.
By their numbers in this assay, from the lowest: compound 1; then compound 3; then compound 2. At a limit, above all of these: compound 4.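

In this assay compound 4 stands at a limit, not a number: the limit of > 100000 nM in this assay, at which 1 of the 4 values shown sits.

Among the compounds shown here, with the thiophen-3-yl ring kept, acetyl in place of hydrogen on the aromatic carbon next to the ring sulfur and next to the ring atom that bears a large group gives an at least 520-fold higher number from compound 1 to compound 4 (2.72 log units; beyond the scatter), the first reading of a single added group at this position. The change from either substituted ring also remains large, with an at least 150-fold higher number from compound 3 to compound 4 (2.18 log units; beyond the scatter) and an at least 19-fold higher number from compound 2 to compound 4 (1.28 log units; beyond the scatter), so 2-acetylthiophen-3-yl sits beyond both 4-methylthiophen-2-yl and 5-formylfuran-2-yl on this read-out.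

The compounds shown leave open whether this result belongs to the acetyl itself or to any group at this position. A methyl or an amine at the same place would separate the two readings, and an acetyl elsewhere on the thiophene would test whether the place matters.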